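Working notes: from compound 3 to compound 4

This account rests on a few compounds, and the source may have more. Where it says the series, first, only, none or still open, it means among the compounds named here.

Measured in a functional assay on LNCaP cells (Homo sapiens) for antiproliferative activity, read by MTT assay, with a stated time of 96 h; a lower number here means a stronger inhibitor, a higher number a weaker inhibitor:
compound 1 `FC(F)(F)Oc1cccc(Nc2nnnc3ccc(N4CCNCC4)nc23)c1`: 8510 nM
compound 2 `CC(C)(C)OC(=O)N1CCC(CNc2ccc3nnnc(Nc4cccc(OC(F)(F)F)c4)c3n2)CC1`: > 100000 nM (a limit)
compound 3 `FC(F)(F)Oc1cccc(Nc2nnnc3ccc(N4CCC(N5CCCC5)CC4)nc23)c1`: 10700 nM

Going by the values given here, compound 3 at 10700 nM and compound 1 at 8510 nM are the only two numbers, and they lie within the scatter of each other. Compound 2 stands at a limit of this assay, not a number: > 100000 nM.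

Next is compound 4 `FC(F)(F)Oc1cccc(Nc2nnnc3ccc(NCC4CCNCC4)nc23)c1`, with ((piperidin-4-yl)methyl)amino in place of 4-(pyrrolidin-1-yl)piperidin-1-yl on an aromatic carbon. Among the compounds with values here, the only measured step at this place is a 1.3-fold higher number from compound 1 to compound 3 (0.10 log units; within the scatter). No step beyond the scatter, in either direction, is therefore expected in this assay. The range stays wide upward, given (the limit of > 100000 nM in this assay, at which 1 of the 3 values shown sits). The estimated step is a 1.1-fold higher number from compound 3 to compound 4 (0.05 log units; within the scatter). For compound 4 the expected value is 12000 nM, with an estimated range of 3500 nM to 45000 nM.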

Compound 4, half-maximal inhibitory concentration: 11500 nM
Compound 4: the middle estimate sits 1.0-fold (0.02 log units) above what was measured; the range from low to high includes it.
By their numbers in this assay, from the lowest: compounds 1, 3 and 4 (each within the scatter of the next). At a limit, above all of these: compound 2.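

In this assay, ((piperidin-4-yl)methyl)amino on this aromatic carbon gives no step beyond the scatter from either ring-linked group: a 1.1-fold higher number from compound 3 to compound 4 (0.03 log units; within the scatter), and a 1.4-fold higher number from compound 1 to compound 4 (0.13 log units; within the scatter). Hydrogen in place of tert-butoxycarbonyl on the ring amine nitrogen gives the first step beyond the scatter in the series: an at least 8.6-fold lower number from compound 2 to compound 4 (0.93 log units; beyond the scatter). The size of that step is bounded, as compound 2 stands at a limit rather than a number: the limit of > 100000 nM in this assay, at which 1 of the 4 values shown sits.

Open, on these data alone, is whether a morpholine or a carboxylic acid at this position would leave the level unchanged. Also open, as far as these compounds go, is whether a longer chain between the amino nitrogen and the piperidine would do so.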